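A few compounds are considered here, and "the series" means these few. Any claim that something is new, unique, unknown or untested is made for them only; others in the source may bear on it.

Working notes on the series. In a functional assay on NIH3T3 cells (Mus musculus) (on this read-out lower numbers stand for an effect already at smaller amounts and higher numbers for an effect only at larger amounts of compound), compound 3 (`CCCCCCC#Cc1cc(C#N)ccc1COC(c1ccc(C#N)cc1)c1cncn1C`) gives > 0.1 nM, which is a limit and not a number. Compound 1 (`Cn1cncc1C(OCc1ccc(C#N)cc1C#Cc1ccccn1)c1ccc(C#N)cc1`) gives > 0.1 nM, also only a limit. Going by the values given here, compound 2 (`Cn1cncc1C(OCc1ccc(C#N)cc1C#CC1(O)CCCCC1)c1ccc(C#N)cc1`) gives 1.93 nM, the only true number so far.

The next change leads to compound 4 (`Cn1cncc1C(OCc1ccc(C#N)cc1-c1ccc(-c2ccccc2)cc1)c1ccc(C#N)cc1`), with 4-phenylphenyl in place of oct-1-yn-1-yl on an aromatic carbon. The triple bond leaves with this change, whereas the measured steps only exchange the group on a triple-bonded carbon, so they bear on it loosely. They are a step that the limit leaves unreadable from compound 1 to compound 2, a step that the two limits leave unreadable from compound 1 to compound 3 and a step that the limit leaves unreadable from compound 2 to compound 3. None has a readable size, so neither a size nor a direction carries over, and no step beyond the scatter can be firmly expected in this assay.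

Among the compounds with values here, the only numerical anchor is compound 2 at 1.93 nM. The expected change, loosely estimated, is a step that the limit leaves unreadable from compound 3 to compound 4. For compound 4 the expected value is 2 nM, with an estimated range of 0.2 nM to 20 nM.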

Compound 4, half-maximal effective concentration: < 0.1 nM
Compound 4 ended at the assay's limit (the forecaster's own chance of this, stated with the estimate: 50%); middle value at least 20-fold (1.30 log units) from the limit.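

In this assay compound 4 gives < 0.1 nM, which is a limit of the assay and not a number. Even so, the series now has its first readable step, an at least 19-fold lower number from compound 2 to compound 4 (1.28 log units; beyond the scatter), with 4-phenylphenyl in place of 2-(1-hydroxycyclohexyl)ethynyl on the aromatic carbon meta to a cyano group. The earlier compounds shown here only exchanged the group on a triple-bonded carbon, whereas compound 4 shows that a triple bond is not required at this position for an effect at small amounts of compound.

The steps of a number no higher from compound 3 to compound 4 (the limit leaves the size open) and a number no higher from compound 1 to compound 4 (the limit leaves the size open) cannot be read in size because the values they start from sit at a limit: the limit of > 0.1 nM in this assay, at which 2 of the 4 values shown sit. The compounds shown do not separate the loss of the triple bond from the entry of the two aromatic rings, and they leave open how a single phenyl, or a 4-phenylphenyl carrying an amine or a carboxylic acid, would read here.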